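This account rests on a few compounds, and the source may have more. Where it says the series, first, only, none or still open, it means among the compounds named here.

Measured so far in an ADME assay on the whole organism with Oryza sativa as the target, tested at 10 uM; a lower number here means a stronger effect, a higher number a weaker effect of the compound at the concentration tested: compound 1 `C[C@H](NC(=O)Nc1ccccc1F)c1ccccc1` with 65%; compound 2 `C[C@@H](NC(=O)Nc1ccc(F)cc1)c1ccccc1` with 92%; compound 3 `C[C@H](NC(=O)Nc1ccccc1Br)c1ccccc1` with 102%.

Compound 1 and compound 3 differ by bromo in place of fluoro on an aromatic carbon, and that change gave a number 37 percentage points higher from compound 1 to compound 3 (beyond the scatter). Compound 2 and compound 1 have the same atoms joined differently; the difference between the two cores is not broken down here. Compound 2 stands within the scatter of compound 3 and beyond the scatter of compound 1.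

Compound 4 `C[C@@H](NC(=O)Nc1ccc(Br)cc1)c1ccccc1` has not yet been measured. It differs from compound 2 by bromo in place of fluoro on an aromatic carbon, the same kind of change as that between compound 1 and compound 3, though in compound 3 the bromo sits ortho to a large group, while in compound 4 it sits para to a large group. Beside a number 37 percentage points higher from compound 1 to compound 3 (beyond the scatter), the expected step is a number 8 percentage points higher from compound 2 to compound 4 (within the scatter). This expectation rests on compound 2 already standing at 92% and on compound 3 reaching 102%. Compound 4 is therefore estimated at 100%, between 85% and 115%.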

Compound 4, a percentage reported as activity, at one concentration (the size of the read-out at that concentration, not a potency): 87%
Beside the measured number, compound 4's estimate is 13 percentage points above it; measured number inside the range.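

In this assay, bromo in place of fluoro on an aromatic carbon gave a number 5 percentage points lower from compound 2 to compound 4 (within the scatter). Within the data shown here, the change therefore did not carry over in size from one core to the other: the same change on two cores in this assay, a number 37 percentage points higher (beyond the scatter) from compound 1 to compound 3 and a number 5 percentage points lower (within the scatter) from compound 2 to compound 4, 42 percentage points apart, beyond the scatter of two such steps This shows that the step seen on the core of compound 1 cannot be assumed on the core of compound 2, but it does not show what separates the two cases, as only one pair stands on each core and the bromo is para to a large group in compound 4 and not in compound 3.

The compounds shown leave open how a chloro or a methoxy group on the same aromatic carbon would read on either core. They also leave open what an amine or a carboxylic acid there would give.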